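Series notes: a further methoxy from compound 2 to compound 3

The source may report more compounds than this note shows. Statements on the series, on what has been measured and on what is new or still open speak of the compounds shown alone.

Measured so far:
compound 1 `NS(=O)(=O)c1ccc(N2N=C(c3cccc(O)c3)C[C@H]2c2ccccc2)cc1` — 77.7%
compound 2 `COc1ccc([C@@H]2CC(c3cccc(O)c3)=NN2c2ccc(S(N)(=O)=O)cc2)cc1OC` — 66.7%

In a functional assay on the whole organism (strain Wistar albino) for inhibition, with Rattus norvegicus as the target, read by paw edema, with stated times of 30 min and 5 h, at a dose of 0.05 mmol/kg (on this read-out lower numbers stand for less inhibition and higher numbers for more inhibition at the one dose given (going by the name of the read-out)), compound 1 gives 77.7%, while compound 2 gives 66.7%. Compound 2 thus stands lowest of the two numbers shown, and the step of a number 11 percentage points lower from compound 1 to compound 2 (beyond the scatter) lies beyond the scatter.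

Compound 3 `COc1cc([C@@H]2CC(c3cccc(O)c3)=NN2c2ccc(S(N)(=O)=O)cc2)cc(OC)c1OC` differs from compound 2 by methoxy in place of hydrogen on an aromatic carbon. Among the measured compounds shown here, the only measured step, a number 11 percentage points lower from compound 1 to compound 2 (beyond the scatter), concerns the same ring and the entry of methoxy groups onto it, so it bears on the present change, though only loosely: it describes two methoxy groups entering at once where compound 3 gains a single further one. A small further lowering, or no step beyond the scatter, is expected, a number 4.7 percentage points lower from compound 2 to compound 3 (within the scatter). For compound 3 the estimate in this assay is 62%, with a range from 50% to 74%.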

Compound 3, a percentage reported as inhibition, in the whole organism at one dose (the size of the read-out at that dose, not a potency): 74.4%
Beside the measured number, compound 3's estimate is 12.4 percentage points below it; measured number outside the range, above it.
By their numbers in this assay, from the lowest: compounds 2, 3 and 1 (each within the scatter of the next, the first and the last beyond it).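

The further methoxy, on an aromatic carbon ortho to a methoxy group and meta to a large group, gives a step within the scatter in this assay (a number 7.7 percentage points higher from compound 2 to compound 3 (within the scatter)). The earlier step on this ring (a number 11 percentage points lower from compound 1 to compound 2 (beyond the scatter)) therefore does not extend to this added methoxy: compound 3 cannot be told apart from compound 2 on this read-out, so a methoxy is accommodated at this position at the one dose given. Nothing available explains this result.

Still open, on these data alone, is whether a hydroxy, an amine or a carboxylic acid in place of this methoxy would stay within the scatter of compound 2. The single-dose percentages also leave any difference in potency between compound 2 and compound 3 unresolved.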